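Working notes on cytotoxicity across four related compounds

The compounds below may be only part of what the source reports. "The series", "measured", "known", "first", "only" and "open" are said of these compounds alone.

Measured so far:
Compound 1 `CCN(CC)C(=S)SC(=S)N(C)C` — in an ADME assay on HeLa cells (Homo sapiens) for cytotoxicity, read by MTT assay, with a stated time of 24 h (a lower number here means a stronger inhibitor, a higher number a weaker inhibitor), compound 1 gives > 5000000 nM, which is a limit of the assay.
Compound 2 `CCN(C)C(=S)SC(=S)N(C)C` — in this assay compound 2 gives 2070000 nM.
Compound 3 `CSC(=S)N1CCN(C(=S)SC(=S)N(C)C)CC1` — in this assay compound 3 gives > 5000000 nM, again a limit of the assay.

From compound 2 to compound 1 the change is methyl in place of hydrogen on a saturated chain carbon bound to an amide-type nitrogen, and the step is an at least 2.4-fold higher number from compound 2 to compound 1 (0.38 log units; beyond the scatter); because of the limit of > 5000000 nM in this assay, at which 2 of the 3 values shown sit, only a lower bound of that step is known. How the core of compound 3 differs from the core of compound 2 is not broken down here.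

Compound 4 `CCSC(=S)N1CCN(C(=S)SC(=S)N(C)C)CC1` is not yet measured. It differs from compound 3 by methyl in place of hydrogen on a saturated chain carbon bound to a sulfur. The place is not the same as in the earlier pair: there the carbon was bound to an amide-type nitrogen, here to a sulfur, so this is the same kind of change, not the same change. Since compound 3 already sits at a limit > 5000000 nM, and the earlier step moved toward the weaker side, compound 4 is expected to remain at or beyond that limit, with an estimated step that the limit leaves unreadable from compound 3 to compound 4. The estimate for compound 4 is 8000000 nM, between 3000000 nM and 30000000 nM.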

Compound 4, half-maximal inhibitory concentration: 4480000 nM
Beside the measured number, compound 4's estimate is 1.8-fold (0.25 log units) above it, within the range that was stated.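

In this assay, methyl in place of hydrogen on a saturated chain carbon bound to a sulfur gives an at least 1.1-fold lower number from compound 3 to compound 4 (0.04 log units; that floor lies within the scatter), and the change does not carry over unaltered from one core to the other: the same change on two cores in this assay, an at least 2.4-fold higher number (0.38 log units; beyond the scatter) from compound 2 to compound 1 and an at least 1.1-fold lower number (0.04 log units; that floor lies within the scatter) from compound 3 to compound 4, at least 2.6-fold (0.43 log units) apart, beyond the scatter of two such steps

This does not give the true size of either step, and the floor of the new step alone does not establish a real fall from its starting compound, since both steps are only bounded: the limit of > 5000000 nM in this assay, at which 2 of the 4 values shown sit.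

It also rests on one pair per core, with the methyl entering on a carbon bound to an amide-type nitrogen in one pair and on a carbon bound to a sulfur in the other, so the cores and the places cannot be told apart as the source of the gap.

Left open is whether the number in this assay would keep moving with a longer chain, such as propylsulfanyl in place of ethylsulfanyl. Also open, from the compounds shown here alone, is how an amine or a carboxylic acid at that end of the shared core would read.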